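Urotensin-2 receptor efficacy notes: from compound 2 to compound 3

The source may hold more compounds than are shown below. What is called first, only, known or untested is meant among the compounds shown, and "the series" means these compounds.

Measured so far:
compound 1 `Cc1ccccc1C(=O)OC(CCN(C)C)c1ccc(Cl)cc1` — 126%
compound 2 `Cc1cc(Br)ccc1C(=O)OC(CCN(C)C)c1ccc(Cl)cc1` — 95%
compound 3 `CN(C)CCC(OC(=O)NCc1ccccc1)c1ccc(Cl)cc1` — not yet measured

In an assay on NIH3T3 cells with Urotensin-2 receptor (Homo sapiens) as the target (on this read-out higher numbers stand for larger maximal responses and lower numbers for smaller maximal responses), compound 1 gives 126%, while compound 2 gives 95%. For the measured compounds named here, the single step between measured compounds, a number 31 percentage points lower from compound 1 to compound 2 (beyond the scatter), is the only change with a known outcome in this assay. Compound 2 therefore stands lowest of the two numbers shown, and its nearest neighbour, compound 1, lies above it beyond the scatter.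

The next compound, compound 3, differs from compound 2 by benzylamino in place of 4-bromo-2-methylphenyl on a carbonyl carbon. Going by the values given here, no measured step bears directly on this change: the one known step concerns bromo on an aromatic carbon, a site that compound 3 does not keep, so its size cannot be transferred. With nothing else to go on, the estimate for compound 3 is anchored on compound 2 and left wide; the step of a number 5 percentage points lower from compound 2 to compound 3 (within the scatter) is expected to stay within the scatter. Compound 3 is thus estimated at 90% in this assay, with a range from 45% to 130%.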

Compound 3, largest response reached (reported as efficacy), in percent of the reference or control that the assay uses: 180%
Compound 3: middle estimate off by 90 percentage points, on the low side; measured number outside the range, above it.
By their numbers in this assay, from the lowest: compound 2; then compound 1; then compound 3.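

On the carbonyl carbon, in this assay, benzylamino in place of 4-bromo-2-methylphenyl gives a number 85 percentage points higher from compound 2 to compound 3 (beyond the scatter), and benzylamino in place of 2-methylphenyl gives a number 54 percentage points higher from compound 1 to compound 3 (beyond the scatter). For the compounds shown here, this position therefore moves the read-out upward, whereas the only earlier change, bromo on an aromatic carbon, moved it down, and compound 3 now stands highest of the three, with its steps to both other compounds beyond the scatter; the exchange keeps the count of heavy atoms and a six-membered aromatic ring of carbon only, while adding one hydrogen-bond donor. No measurement in hand accounts for the rise.

The compounds shown cannot separate the contribution of the added hydrogen-bond donor from that of the changed connection to the aromatic ring, and benzyl(methyl)amino, which has no such donor, or anilino, which has no methylene link, would address those two points. Also open, on these data alone, is whether bromo on the aromatic ring of benzylamino would lower the number as it did in the earlier step, or whether a longer chain such as phenethylamino would hold the response at this level.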